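From Methyl to Hydroxy: Compound 1 to Compound 3

This account rests on a few compounds, and the source may have more. Where it says the series, first, only, none or still open, it means among the compounds named here.

Compound 1 `Cc1ccc(/C=C(/C#N)C(=O)c2ccc[nH]2)cc1` was tested in a functional assay on BE(2)-C cells (Homo sapiens) for cytotoxicity, read by MTT assay, with a stated time of 72 h (a higher number here means a weaker inhibitor of growth, a lower number a stronger inhibitor of growth), where compound 1 gives 11000 nM. Its companion compound 2 `N#C/C(=C/c1ccc(Cl)c(Cl)c1)C(=O)c1ccc[nH]1` gives 14000 nM in this assay. The number for compound 1 is the lower of the two, yet the two lie within the usual scatter of each other, so no order between them is claimed. Compound 3 `N#C/C(=C/c1ccc(O)cc1)C(=O)c1ccc[nH]1` carries one change relative to compound 1: hydroxy in place of methyl on an aromatic carbon. Among the compounds with values here, no measured step of this kind exists here, so the step of a 1.1-fold lower number from compound 1 to compound 3 (0.04 log units; within the scatter) is expected to stay within the scatter, in no settled direction. Compound 3 is therefore estimated at 10000 nM, within 3000 nM to 35000 nM.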

Compound 3, concentration for 50% growth inhibition: < 10000 nM
Compound 3 was reported as a limit; the forecaster's own chance of this, stated with the estimate: 10%; the middle value lies on the limit itself.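

Compound 3 stands in this assay only as a limit, < 10000 nM. Replacing methyl with hydroxy on an aromatic carbon, para to a large group, gives the first step read at this position: an at least 1.1-fold lower number from compound 1 to compound 3 (0.04 log units; that floor lies within the scatter). The true size of the step stays unknown, since the reading is bounded on one side only: the limit of < 10000 nM in this assay, at which 1 of the 3 values shown sits.

The compounds shown leave open how a methoxy group or an amine at this place would read in this assay.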